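A pyrimidin-2-yl swap at the limit of measurement

A few compounds are considered here, and "the series" means these few. Any claim that something is new, unique, unknown or untested is made for them only; others in the source may bear on it.

Values so far in a functional assay on VCaP cells (Homo sapiens) for antiproliferative activity, read by CCK-8 assay, with a stated time of 6 days; a higher number here means a weaker inhibitor, a lower number a stronger inhibitor

- Compound 1 `C[C@@H](Cn1ccc(-c2ccc(C#N)c(Cl)c2)n1)NC(=O)c1ccccc1F` gives 2190 nM
- Compound 2 `COC(=O)/C=C/C(=O)N[C@@H](C)Cn1ccc(-c2ccc(C#N)c(Cl)c2)n1` gives 5230 nM
- Compound 3 `C[C@@H](Cn1ccc(-c2ccc(C#N)c(Cl)c2)n1)Nc1cccnc1` gives > 30000 nM as a limit

Compound 3 is the weakest of the three, and its value > 30000 nM is a limit and not a number.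

Compound 4 `C[C@@H](Cn1ccc(-c2ccc(C#N)c(Cl)c2)n1)Nc1ncccn1` carries pyrimidin-2-yl in place of pyridin-3-yl on the amine nitrogen pyrimidin-2-yl in place of pyridin-3-yl on an amine nitrogen and is otherwise unchanged.

Among the measured compounds shown here, no measured step makes this exact swap. The closest evidence is the large step of an at least 13-fold higher number from compound 1 to compound 3 (1.13 log units; beyond the scatter) together with the at least modest step an at least 5.7-fold higher number from compound 2 to compound 3 (0.75 log units; beyond the scatter) and in both a carbonyl-bearing group on that nitrogen gives way to pyridin-3-yl. Compound 4 also lacks that carbonyl, so a return towards compound 1 at 2190 nM is not expected. Any visible change could only be towards a lower number in this assay but no step beyond the scatter is expected.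

The estimated change is an at least 1.5-fold lower number from compound 3 to compound 4 (0.17 log units; that floor lies within the scatter) and remains tentative.

For compound 4 the expected value is 20000 nM with an estimated range of 7000 nM to 30000 nM and a report of only a limit would be no surprise.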

Compound 4, half-maximal inhibitory concentration: 480 nM
Beside the measured number, compound 4's estimate is 42-fold (1.62 log units) above it, outside the stated range (below it).
By their numbers in this assay, from the lowest: compound 4; then compound 1; then compound 2. At a limit, above all of these: compound 3.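

In this assay, pyrimidin-2-yl in place of pyridin-3-yl on the amine nitrogen gives an at least 62-fold lower number from compound 3 to compound 4 (1.79 log units; beyond the scatter), so this position is highly sensitive to which six-membered aromatic ring it carries. That step is a floor and not an exact size, as compound 3 is reported only as a limit: the limit of > 30000 nM in this assay, at which 1 of the 4 values shown sits. The earlier steps shown here from compounds with a carbonyl on this nitrogen to compound 3 all pointed to a loss, but compound 4 has no such carbonyl and still gives an 11-fold lower number from compound 2 to compound 4 (1.04 log units; beyond the scatter) and a 4.6-fold lower number from compound 1 to compound 4 (0.66 log units; beyond the scatter), so a carbonyl there is not required.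

Going by these compounds, it remains open whether the difference follows from the second ring nitrogen or from where the ring is attached. Pyridin-2-yl and pyrimidin-5-yl on the same nitrogen would help separate these two possibilities.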